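Benzisoxazole-free account: carboxylic acids against inositol hexakisphosphate kinase 3

The compounds below may be only part of what the source reports. "The series", "measured", "known", "first", "only" and "open" are said of these compounds alone.

Compound 1 `COC(=O)/C=C/c1ccc2noc(-c3ccccc3)c2c1`: 12100 nM
Compound 2 `Cc1ccc(-c2onc3ccc(/C=C/C(=O)O)cc23)cc1`: 11500 nM
Compound 3 `O=C(O)c1ccc2noc(-c3ccc(N4CCCCC4)cc3)c2c1`: 1790 nM

The three measured compounds share a core and were tested in an assay for inhibition of inositol hexakisphosphate kinase 3 (Homo sapiens), read by colorimetric assay, coupled enzyme assay and malachite green, with a stated time of 120 min, in the presence of a further agent that is not named here; on this read-out lower numbers stand for stronger inhibition and higher numbers for weaker inhibition. Compound 1 gives 12100 nM and compound 2 gives 11500 nM; these two lie within the scatter of each other, so no order between them is claimed. Compound 3, with its piperidin-1-yl group, gives 1790 nM, the lowest of the three numbers, and its steps to both of the others are printed as beyond the scatter, so it stands as the strongest inhibitor of the set.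

Compound 4 `O=C(O)c1ccc2noc(-c3ccc(NC(=O)C4CCCC4)cc3)c2c1` has not yet been measured. It differs from compound 3 in a single place: (cyclopentylcarbonyl)amino in place of piperidin-1-yl on an aromatic carbon. The tertiary amine nitrogen of the piperidine leaves and an amide with a cyclopentyl ring enters, bringing a hydrogen-bond donor that compound 3 lacks.

Going by the values given here, no step between measured compounds offers a guide to this kind of change, so the expectation rests on compound 3 alone. The step of a 1.7-fold higher number from compound 3 to compound 4 (0.22 log units; within the scatter) is expected to be modest, tending toward weaker inhibition, though it may well fall within the scatter. Compound 4 is accordingly estimated at 3000 nM, with a range from 900 nM to 10000 nM.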

Compound 4, half-maximal inhibitory concentration: 240 nM
Beside the measured number, compound 4's estimate is 13-fold (1.10 log units) above it, and the stated range ends above it.
By their numbers in this assay, from the lowest: compound 4; then compound 3; then compounds 2 and 1 (each within the scatter of the next).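

With (cyclopentylcarbonyl)amino in place of piperidin-1-yl, this assay records a 7.5-fold lower number from compound 3 to compound 4 (0.87 log units; beyond the scatter). Going by these compounds alone, this gives the first single-place comparison in the set and shows that the group on this aromatic carbon, para to a large group, can move the number beyond the scatter, which the earlier compounds, differing from one another in more than one place, could not show on their own. The change swaps a six-membered ring for a five-membered carbon ring and adds a carbonyl and the amide hydrogen all at once, and nothing shown ties the lower number to any one of these features.

The compounds shown leave open which part of the entering group matters: an acetylamino group would test the amide without the cyclopentyl ring, and an amide whose nitrogen carries a methyl group would test the role of the amide hydrogen. Going by these compounds, it also remains open whether (cyclopentylcarbonyl)amino would give a similar step on a compound carrying a methyl ester in place of the carboxylic acid.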